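From fluoro to methyl at a solubility limit

The compounds below may be only part of what the source reports. "The series", "measured", "known", "first", "only" and "open" are said of these compounds alone.

- Compound 1 `O=C(O)c1ccc(C(=O)/C(=C\c2ccc(F)c([N+](=O)[O-])c2)S(=O)(=O)Cc2ccc(Br)cc2)cc1` gives < 1000 ug/mL as a limit
- Compound 2 `O=C(O)c1ccc(C(=O)/C(=C\c2ccc(F)c([N+](=O)[O-])c2)SCc2ccc(F)cc2)cc1` gives < 1000 ug/mL as a limit

In a physicochemical assay for solubility (on this read-out higher numbers stand for higher solubility and lower numbers for lower solubility), compound 2 stands at < 1000 ug/mL which is a limit and not a number. That limit holds both measured compounds (the limit of < 1000 ug/mL in this assay, at which 2 of the 2 values shown sit). Compound 3 `Cc1ccc(CS/C(=C/c2ccc(F)c([N+](=O)[O-])c2)C(=O)c2ccc(C(=O)O)cc2)cc1` carries methyl in place of fluoro on an aromatic carbon, para to a large group (methyl in place of fluoro on an aromatic carbon). For the measured compounds named here, the only measured step (a step that the two limits leave unreadable from compound 1 to compound 2) offers no size to carry over, so no step beyond the usual scatter is expected in this assay and no direction is claimed. The estimated step (a step that the limit leaves unreadable from compound 2 to compound 3) is correspondingly small. Compound 3 is expected at 500 ug/mL with an estimated range from 150 ug/mL to 1000 ug/mL and will probably be reported as a limit too.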

Compound 3, solubility: < 1000 ug/mL
Compound 3 gave a limit, no number; the forecaster's own chance of this, stated with the estimate: 90%; the middle value is on the limit's open side.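

In this assay compound 3 gives < 1000 ug/mL, a limit and not a number, so no step to compound 1 or compound 2 can be read: the limit of < 1000 ug/mL in this assay, at which 3 of the 3 values shown sit.

The compounds shown leave open whether methyl in place of fluoro changes the read-out at all, and how compound 1, compound 2 and compound 3 actually compare.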